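A few compounds are considered here, and "the series" means these few. Any claim that something is new, unique, unknown or untested is made for them only; others in the source may bear on it.

Measured in a functional assay on A-375 cells (Homo sapiens) for cytotoxicity, read by MTT assay, with a stated time of 72 h; on this read-out lower numbers stand for stronger inhibition and higher numbers for weaker inhibition:

- Compound 1 `O=C1c2c[n+]([O-])c3ccccc3c2C(=O)c2c1c1ccccc1n2CCCCn1ccnc1`: 350 nM
- Compound 2 `O=C1c2c[n+]([O-])c3ccccc3c2C(=O)c2c1c1ccccc1n2Cc1cn(C[C@H](O)CO)nn1`: 350 nM
- Compound 3 `CC1(C)OCC(Cn2cc(Cn3c4c(c5ccccc53)C(=O)c3c[n+]([O-])c5ccccc5c3C4=O)nn2)O1`: 330 nM

Compound 2, at 350 nM, stands level with compound 1, and compound 3 lies within the scatter of both. Compound 4 `CN1CCN(CCCCn2c3c(c4ccccc42)C(=O)c2c[n+]([O-])c4ccccc4c2C3=O)CC1` keeps the shared core and departs from compound 2 at one place: 3-(4-methylpiperazin-1-yl)propyl in place of 1-(2,3-dihydroxypropyl)-1H-1,2,3-triazol-4-yl on a saturated chain carbon bound to an aromatic nitrogen. Here 3-(4-methylpiperazin-1-yl)propyl comes in place of 1-(2,3-dihydroxypropyl)-1H-1,2,3-triazol-4-yl, on a saturated chain carbon bound to an aromatic nitrogen.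

Among the compounds with values here, two measured steps bear on this change. The closer one exchanged 3-(1H-imidazol-1-yl)propyl for the same triazole group at the same place, and it gave no change at the digits printed from compound 1 to compound 2 (within the scatter). The other altered only the end of the triazole substituent and gave a 1.1-fold lower number from compound 2 to compound 3 (0.03 log units; within the scatter). Neither step moved the number beyond the scatter in this assay. However, no measured compound carries a non-aromatic ring at this place, so the evidence is indirect and the range must stay wide. On the strength of these two steps, no shift beyond the scatter is expected, and the estimated step is a 1.2-fold lower number from compound 2 to compound 4 (0.07 log units; within the scatter). Compound 4 is expected at 300 nM, with an estimated range of 110 nM to 800 nM.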

Compound 4, half-maximal inhibitory concentration: 30 nM
For compound 4 the middle estimate is 10-fold (1.00 log units) above the measured one; measured number outside the range, below it.
By their numbers in this assay, from the lowest: compound 4; then compounds 3, 1 and 2 (each within the scatter of the next).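

Within the data shown here, compound 4 shows that this place on the chain is not indifferent to the group it carries: the imidazole and triazole groups of the earlier compounds left the number within the scatter, whereas 3-(4-methylpiperazin-1-yl)propyl in place of the triazole group gives a 12-fold lower number from compound 2 to compound 4 (1.07 log units; beyond the scatter) in this assay and so marks the first step beyond the scatter in this set. The comparison with compound 1 is the narrower one, since both compounds carry the same chain and differ only in the group at its end, on a saturated chain carbon four bonds along the chain from an aromatic nitrogen; there 4-methylpiperazin-1-yl in place of 1H-imidazol-1-yl gives a 12-fold lower number from compound 1 to compound 4 (1.07 log units; beyond the scatter) and places the change in that end group. No measurement offered here explains why this end group stands apart from the others.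

The compounds shown leave open whether the whole 4-methylpiperazin-1-yl group is needed, which a morpholine or a piperazine without the methyl group on the same chain would test. They also leave open how the result depends on chain length, which a shorter or longer chain ending in 4-methylpiperazin-1-yl would address.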